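Pyridinone series: removing the sulfonamide-bearing side chain

The compounds below may be only part of what the source reports. "The series", "measured", "known", "first", "only" and "open" are said of these compounds alone.

Measured so far in a functional assay (aorta) for antagonist activity, with Oryctolagus cuniculus as the target; on this read-out lower numbers stand for stronger inhibition and higher numbers for weaker inhibition:
compound 1, `CCCCc1ccc(CN)c(=O)n1Cc1ccc(-c2ccccc2-c2nn[nH]n2)cc1`, 20 nM
compound 2, `CCCCc1ccc(CN(C)S(C)(=O)=O)c(=O)n1Cc1ccc(-c2ccccc2-c2nn[nH]n2)cc1`, 0.2 nM

Compound 2 stands at the lowest of the two numbers in this assay; its nearest neighbour is compound 1, and the gap between the two lies beyond the scatter. Going by the values given here, the one measured step, a 100-fold lower number from compound 1 to compound 2 (2.00 log units; beyond the scatter), shows that the group on the saturated chain carbon bound to the aromatic carbon matters greatly for this read-out.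

Compound 3, `CCCCc1cccc(=O)n1Cc1ccc(-c2ccccc2-c2nn[nH]n2)cc1`, removes that whole side chain: hydrogen in place of (methyl(methylsulfonyl)amino)methyl on an aromatic carbon. Among the compounds with values here, no measured pair covers the loss of the full chain, so the only guide is the step from compound 1 to compound 2, which moved the number a great deal on exchange of amino for methyl(methylsulfonyl)amino. With nothing at all in that place, the number is expected to rise at least as far as compound 1 sits, and likely further; the step of a 200-fold higher number from compound 2 to compound 3 (2.30 log units; beyond the scatter) is the estimated outcome. Compound 3 is therefore expected to give about 40 nM, within a range of 5 nM to 300 nM.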

Compound 3, half-maximal inhibitory concentration: 4 nM
The estimate for compound 3 lay 10-fold (1.00 log units) above the measured number, outside the stated range (below it).
By their numbers in this assay, from the lowest: compound 2; then compound 3; then compound 1.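

Hydrogen on this aromatic carbon gives the series its first reference point for the side chain in this assay: the full (methyl(methylsulfonyl)amino)methyl group is not merely better than aminomethyl but also clearly better than no chain at all, as the removal shows (a 20-fold higher number from compound 2 to compound 3 (1.30 log units; beyond the scatter)). Aminomethyl falls on the other side of that reference, since replacing it with hydrogen improves the read-out (a 5.0-fold lower number from compound 1 to compound 3 (0.70 log units; beyond the scatter)), so a substituent in this place can either raise or lower the number relative to hydrogen, and the large step between compound 1 and compound 2 spans both directions rather than a gain from a neutral baseline. No supporting data bear on why these two chains part in opposite directions.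

Still open, as far as these compounds go, is whether the gain in compound 2 rests on the methylsulfonyl group, on the methyl on nitrogen or on the two together. Also open, from the compounds shown here alone, is where a plain methyl, a hydroxymethyl, a carboxylic acid or a longer chain on this carbon would fall relative to compound 3.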